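Para-fluoro to hydrogen in the anilide series

The compounds below may be only part of what the source reports. "The series", "measured", "known", "first", "only" and "open" are said of these compounds alone.

The shared core of compound 1 `COc1cc(NC(=O)CSc2nc3cccnc3[nH]2)cc(OC)c1` carries a trimethoxyphenyl-free dimethoxy anilide; in an assay on isolated protein for inhibition of Ectonucleotide pyrophosphatase/phosphodiesterase family member 1 (Homo sapiens), tested at 10 uM (a lower number here means less inhibition, a higher number more inhibition at the concentration tested (going by the name of the read-out)), compound 1 gives 38%. Compound 2 `O=C(CSc1nc2cccnc2[nH]1)Nc1ccc(F)cc1` carries the 4-fluorophenyl amide instead, and in this assay compound 2 gives 30%. Among the two numbers measured, compound 2 sits at the bottom, with compound 1 as its nearest neighbour, and the gap between them lies within the usual scatter, so no ranking is drawn from it.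

Compound 3 `O=C(CSc1nc2cccnc2[nH]1)Nc1ccccc1` has not yet been measured in this assay. It differs from compound 2 by hydrogen in place of fluoro on an aromatic carbon, so the 4-fluorophenyl becomes a plain phenyl. Among the measured compounds shown here, no step between measured compounds exists to size this kind of change, and the two numbers in hand offer no trend to lean on. The change removes one heavy atom only, and the expectation is for a small step, if any, no larger than the scatter, estimated as a number 3 percentage points lower from compound 2 to compound 3 (within the scatter). For compound 3 the estimate in this assay is 27%, with a range from 10% to 45%.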

Compound 3, a percentage reported as inhibition, at one concentration (the size of the read-out at that concentration, not a potency): 30%
Compound 3: middle estimate off by 3 percentage points, on the low side, and the stated range covers the measured number.
By their numbers in this assay, from the lowest: compounds 2, 3 and 1 (each within the scatter of the next).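

In this assay, among the compounds shown here, hydrogen in place of fluoro on an aromatic carbon, para to a large group, gives no change at the digits printed from compound 2 to compound 3 (within the scatter); this is the first comparison between compounds that differ in one place only. At this position, then, the 4-fluorophenyl and the plain phenyl cannot be told apart at the single concentration tested, and fluoro is not required for the read-out to stay at this level. For the compounds shown here, no measurement at hand accounts for this result, and it sizes only this one exchange, not substitution at this position in general.

The compounds shown leave open whether a larger or differently functionalised group on this carbon, such as an amine, a carboxylic acid or a longer chain, would move the read-out beyond the scatter. On these data alone, compound 1 differs from compound 3 in more than one place, so the contribution of its two methoxy groups also remains open, and no step can be read for that pair.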